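Phenyl for ring hydrogen: outlook for compound 3

The source may report more compounds than this note shows. Statements on the series, on what has been measured and on what is new or still open speak of the compounds shown alone.

Compound 1 `Cc1cc2nn(-c3ccccc3)c(N)c2c(=O)[nH]1` is the reference point of the series. For the measured compounds named here, in an assay on isolated protein for inhibition of MAP kinase-activated protein kinase 2 (Homo sapiens), read by mobility shift assay, tested at 30 uM (a higher number here means more inhibition at the concentration tested (going by the name of the read-out), a lower number less inhibition), compound 1 gives -4%, the lower of the two numbers so far; the nearest is compound 2 `Nc1c2c(=O)[nH]c(-c3ccccc3)cc2nn1-c1ccccc1`, which in this assay gives 2%. Going by the values given here, the only measured step, a number 6 percentage points higher from compound 1 to compound 2 (within the scatter), lies within the scatter, so the two values cannot be ordered.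

Compound 3 `Cc1[nH]c(=O)c2c(N)n(-c3ccccc3)nc2c1-c1ccccc1` differs from compound 1 as follows: phenyl in place of hydrogen on an aromatic carbon. Among the compounds with values here, no measured step shares this place of change; the step from compound 1 to compound 2 puts phenyl in place of methyl on an aromatic carbon and bears on compound 3 only as the single example of a phenyl entering the shared core, and it was a number 6 percentage points higher from compound 1 to compound 2 (within the scatter), within the scatter. Both measured values sit near zero inhibition, and nothing in the data suggests that an added phenyl moves the number beyond the scatter. For compound 3 the step of a number 4 percentage points higher from compound 1 to compound 3 (within the scatter) is therefore expected to stay within the scatter. The estimate for compound 3 in this assay is 0%, with a range from -12% to 12%.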

Compound 3, a percentage reported as inhibition, at one concentration (the size of the read-out at that concentration, not a potency) in the MAP kinase-activated protein kinase 2 assay: 9%
The estimate for compound 3 lay 9 percentage points below the measured number; the range from low to high includes it.
By their numbers in the MAP kinase-activated protein kinase 2 assay, from the lowest: compounds 1, 2 and 3 (each within the scatter of the next, the first and the last beyond it).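

Phenyl in place of hydrogen on this aromatic carbon, ortho to a methyl group, gives in the MAP kinase-activated protein kinase 2 assay a number 13 percentage points higher from compound 1 to compound 3 (beyond the scatter), the first step in the series to lie beyond the scatter. The earlier step changed a methyl group at another place on the shared core and could not be read, so this position is the only one shown so far where a new group moves the number, although compound 3 at 9% still shows only slight inhibition at a single tested concentration and gives no potency. The same change has a clear cost in a physicochemical assay for solubility, read by HPLC (a higher number here means a more soluble compound, a lower number a less soluble compound), where compound 1 gives 69 ug/mL and compound 3 gives 7 ug/mL and where phenyl in place of hydrogen at this position lowers solubility: the measured solubility of compound 1, 69 ug/mL, and of compound 3, 7 ug/mL, a 9.9-fold lower number (0.99 log units; beyond the scatter)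

Only hydrogen and phenyl are shown on this carbon, so it remains open whether the small rise in inhibition is specific to phenyl or would also come with other groups. An amine, a carboxylic acid, a morpholine ring or a short chain such as ethyl at this position would show whether inhibition and solubility must move in opposite directions here.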